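A few compounds are considered here, and "the series" means these few. Any claim that something is new, unique, unknown or untested is made for them only; others in the source may bear on it.

Measured compounds:
compound 1, `Brc1ccc(OCCOc2nc3ccccc3s2)c(Br)c1`: 68.6%
compound 2, `Cc1ccc(COc2nc3ccccc3s2)cc1`: "not active" (no number reported)

In a functional assay on the whole organism with Mus musculus as the target, in the writhing test, at a dose of 100 mg/kg by the intraperitoneal route (on this read-out lower numbers stand for less inhibition and higher numbers for more inhibition at the one dose given (going by the name of the read-out)), compound 1 gives 68.6%, while compound 2 is reported only as "not active" (no number reported), so no single number stands for compound 2 and it has no place on the scale. Compound 3, `Fc1ccc(COc2nc3ccccc3s2)cc1`, differs from compound 2 by fluoro in place of methyl on an aromatic carbon. Among the measured compounds shown here, no step between measured compounds is known, so the size and direction of this change in this assay can only be guessed, and a step within the scatter seems most likely. With compound 2 giving no number, the expectation for compound 3 stays low: compound 3 is expected at about 15%, between 0% and 40%.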

Compound 3, a percentage reported as inhibition, in the whole organism at one dose (the size of the read-out at that dose, not a potency): 51.9%
Estimate against measurement, compound 3: 36.9 percentage points below, outside the stated range (above it).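

Among the compounds shown here, compound 2 carries no number in this assay, so no step to compound 3 can be read. The compounds shown leave open how far fluoro in place of methyl shifts the inhibition, and no measured evidence bears on this result.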